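A few compounds are considered here, and "the series" means these few. Any claim that something is new, unique, unknown or untested is made for them only; others in the source may bear on it.

Working notes on the series. Among the measured compounds shown here, in a functional assay on SK-BR-3 cells (Homo sapiens) for antiproliferative activity (on this read-out higher numbers stand for weaker inhibition and lower numbers for stronger inhibition), compound 1 `CC(C)=CCc1cc(C(=O)Nc2cc3ccc(OCC4CCCNC4)c(C)c3oc2=O)ccc1O` gives 600 nM and compound 2 `CC(C)=CCc1cc(C(=O)Nc2cc3ccc(OCCCNCC(N)=O)c(C)c3oc2=O)ccc1O` gives 2290 nM, so compound 2 holds the higher of the two numbers so far. Next to be measured is compound 3 `CC(C)=CCc1cc(C(=O)Nc2cc3ccc(OCCCNCCO)c(C)c3oc2=O)ccc1O`, which differs from compound 2 as follows: hydroxymethyl in place of carbamoyl on a saturated chain carbon bound to an amine nitrogen. Hydroxymethyl stands in place of carbamoyl on a saturated chain carbon bound to an amine nitrogen, which turns carbamoylmethyl into 2-hydroxyethyl.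

For the measured compounds named here, only one measured step bears on this, and only indirectly: a 3.8-fold higher number from compound 1 to compound 2 (0.58 log units; beyond the scatter). That modest step exchanges piperidin-3-yl for 2-((carbamoylmethyl)amino)ethyl, a larger exchange than the one at hand. Going by the values given here, no measured step touches the carbamoyl group alone, so the direction is poorly supported. Measured against a 3.8-fold higher number from compound 1 to compound 2 (0.58 log units; beyond the scatter), a smaller step is expected in this assay, most likely none beyond the scatter, with a slight lean towards a lower number. The estimated step is a 1.3-fold lower number from compound 2 to compound 3 (0.10 log units; within the scatter). For compound 3 the estimated value is 1800 nM, with an expected range from 700 nM to 4500 nM.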

Compound 3, half-maximal inhibitory concentration: 610 nM
For compound 3 the middle estimate is 3.0-fold (0.47 log units) above the measured one, and the stated range ends above it.
By their numbers in this assay, from the lowest: compounds 1 and 3 (each within the scatter of the next); then compound 2.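

In this assay, hydroxymethyl in place of carbamoyl on a saturated chain carbon bound to an amine nitrogen gives a 3.8-fold lower number from compound 2 to compound 3 (0.57 log units; beyond the scatter), so this one group change matters on its own, which the earlier pair, with its exchange of the whole piperidin-3-yl group, could not show. With a 1.0-fold higher number from compound 1 to compound 3 (0.01 log units; within the scatter), 2-((2-hydroxyethyl)amino)ethyl and piperidin-3-yl cannot be told apart here, so among these three compounds, replacing piperidin-3-yl with an open chain does not by itself go with the higher number of compound 2; that number appears only with the carbamoyl group present. Nothing available explains why the carbamoyl and hydroxymethyl compounds differ.

On these data alone, it remains open whether a methoxy group, a primary amine or a carboxylic acid in place of the hydroxyl of 2-hydroxyethyl would read like compound 3 or like compound 2. Also open, as far as these compounds go, is whether a longer chain carrying the hydroxyl, or an ether oxygen in place of the amine nitrogen, would keep the value of compound 3 in this assay.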